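A few compounds are considered here, and "the series" means these few. Any claim that something is new, unique, unknown or untested is made for them only; others in the source may bear on it.

Measured compounds:
- compound 1 `COc1cc2c(cc1CC=C(C)C)/C(=N/NC(N)=O)C[C@@H](c1ccc(O)cc1)O2` gives 77%
- compound 2 `COc1ccc([C@@H]2C/C(=N/OCc3cn(-c4ccc(Cl)cc4C)nn3)c3cc(CC=C(C)C)c(OC)cc3O2)cc1` gives 35%

Both compounds were tested in a functional assay on A549 cells (Homo sapiens) for inhibition, read by sulforhodamine B assay, with a stated time of 48 h, tested at 50 uM; a lower number here means less inhibition of growth, a higher number more inhibition of growth at the concentration tested. Compound 2 stands at the lower of the two numbers; compound 1 lies well above it, and that gap is beyond the usual scatter of this measurement. Within the data shown here, since only these two values exist and no pair differing in a single place has been measured, nothing shows how large a single change tends to move the result.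

Compound 3 `COc1ccc([C@@H]2C/C(=N/OCc3cn(-c4ccccc4CO)nn3)c3cc(CC=C(C)C)c(OC)cc3O2)cc1` has not yet been measured. It differs from compound 2 in one place: 2-(hydroxymethyl)phenyl in place of 4-chloro-2-methylphenyl on an aromatic nitrogen. With no comparable change among the measured compounds to lean on, the expected step of no change at the digits printed from compound 2 to compound 3 (within the scatter) is none beyond the scatter, in no clear direction. Compound 3 is therefore estimated at 35%, with a range from 15% to 60%.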

Compound 3, percent growth inhibition at one concentration: 100%
Beside the measured number, compound 3's estimate is 65 percentage points below it, outside the stated range (above it).
By their numbers in this assay, from the lowest: compound 2; then compound 1; then compound 3.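

In this assay, placing 2-(hydroxymethyl)phenyl instead of 4-chloro-2-methylphenyl on the aromatic nitrogen gives a number 65 percentage points higher from compound 2 to compound 3 (beyond the scatter). This shows that the group at this position is far from a passive passenger: exchanging one substituted phenyl for another, each with 8 heavy atoms, can move the result by a large step while the rest of the molecule stays the same. No measurement shown explains why this exchange has such a large effect.

The exchange removes the chlorine and replaces the methyl with hydroxymethyl in a single step, so the compounds shown cannot tell which of these two differences accounts for the step. On these data alone, it also remains open how an aminomethyl group or a carboxylic acid would read in place of the hydroxymethyl group.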